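The compounds below may be only part of what the source reports. "The series", "measured", "known", "first", "only" and "open" are said of these compounds alone.

Values in an ADME assay (liver) for metabolic stability, with Liver microsome (Rattus norvegicus) as the target, read by LC-MS, using microsomes, with a stated time of 30 min, tested at 4 uM (on this read-out lower numbers stand for a less stable compound and higher numbers for a more stable compound), follow

compound 1 `Cc1nc(N2CCN(C)CC2)c2nc(-c3ccccc3Cl)n(CCO)c2n1` gives 6%
compound 2 `Cc1nc(N2CCN(C)CC2)c2nc(-c3ccccc3C(F)(F)F)n(C3CCOCC3)c2n1` gives 38%

Compound 2 stands highest of the two numbers, beyond the scatter from compound 1. Compound 3 `COc1cccc(-c2nc3c(N4CCN(C)CC4)nc(C)nc3n2C2CCOCC2)c1` differs from compound 2 by 3-methoxyphenyl in place of 2-(trifluoromethyl)phenyl on an aromatic carbon with 3-methoxyphenyl in place of 2-(trifluoromethyl)phenyl on an aromatic carbon. Among the measured compounds shown here, no measured step isolates this change. The low value of compound 1 (6%) shows that numbers well under that of compound 2 occur with this core, though compound 1 differs in more than one place. A moderate fall is expected, with a number 12 percentage points lower from compound 2 to compound 3 (beyond the scatter) estimated to lie slightly beyond the scatter. Compound 3 is estimated at 26% (range 10% to 46%).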

Compound 3, percent of the compound remaining: 30%
Compound 3: the middle estimate sits 4 percentage points below what was measured; the range from low to high includes it.
By their numbers in this assay, from the lowest: compound 1; then compounds 3 and 2 (each within the scatter of the next).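

In this assay, among the compounds shown here, 3-methoxyphenyl in place of 2-(trifluoromethyl)phenyl on this aromatic carbon gives a number 8 percentage points lower from compound 2 to compound 3 (within the scatter), the first single-place step. With the oxan-4-yl group held constant, this position therefore accepts this exchange of phenyl groups with no difference outside the scatter. Nothing measured bears on a cause for this result.

The step changes both the substituent and its place on the phenyl ring, so the two remain unseparated. Also open, as far as these compounds go, is how an amine or a carboxylic acid on that phenyl ring would read.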